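Swapping Furan for Thiophene on a Shared Core

The source may report more compounds than this note shows. Statements on the series, on what has been measured and on what is new or still open speak of the compounds shown alone.

Of the compounds shown here, three have been measured in a functional assay on K562 cells (Homo sapiens) for inhibition, read by thymidine incorporation, with a stated time of 48 h, tested at 10 ug/mL; a higher number here means more inhibition at the concentration tested (going by the name of the read-out), a lower number less inhibition. Compound 1 `C(#Cc1[nH]cnc2ncnc1-2)c1ccccc1` gives 100%, compound 2 `COc1ccc(/C=C/c2ncnc3c2ncn3C2CCOCC2)cc1` gives 58%, and compound 3 `C(=C/c1ncnc2c1ncn2C1CCOCC1)\c1ccco1` gives 35%, the lowest of the three numbers. Compounds 2 and 3 share a core and differ in one place: a number 23 percentage points lower from compound 2 to compound 3 (beyond the scatter). Compound 4 `C(=C/c1ncnc2c1ncn2C1CCOCC1)\c1ccsc1` is the next step from compound 3: thiophen-3-yl in place of furan-2-yl on a double-bonded chain carbon bound to a double-bonded chain carbon. For the measured compounds named here, no measured step exchanges one five-membered aromatic ring for another, so the only related evidence is the modest drop from compound 2 to compound 3, which replaced a six-membered ring, not a five-membered one. For compound 4 the expected step is therefore a number 5 percentage points higher from compound 3 to compound 4 (within the scatter), a change within the scatter. Compound 4 is thus estimated at 40%, between 20% and 60%.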

Compound 4, a percentage reported as inhibition, at one concentration (the size of the read-out at that concentration, not a potency): 58%
Estimate against measurement, compound 4: 18 percentage points below; low and high end bracket the measured number.
By their numbers in this assay, from the lowest: compound 3; then compounds 2 and 4 (each within the scatter of the next); then compound 1.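

Two rings with the same heavy-atom count and one hetero atom each are not interchangeable on this double-bonded chain carbon: thiophen-3-yl in place of furan-2-yl gives a number 23 percentage points higher from compound 3 to compound 4 (beyond the scatter) in this series. Thiophen-3-yl in place of 4-methoxyphenyl gives no change at the digits printed from compound 2 to compound 4 (within the scatter) so a five-membered ring does not by itself lower the number. No available evidence explains the difference between the two rings.

Furan-3-yl or thiophen-2-yl could show whether the step goes with the hetero atom or the point of attachment. From the compounds shown here alone, how pyridin-3-yl would fare here also remains open.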